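Removing a Chain Methyl in Two Related Compound Pairs

A few compounds are considered here, and "the series" means these few. Any claim that something is new, unique, unknown or untested is made for them only; others in the source may bear on it.

In a functional assay on the whole organism (stomach) with Rattus norvegicus as the target (on this read-out higher numbers stand for an effect only at larger amounts of compound and lower numbers for an effect already at smaller amounts), compound 1 `C/N=C(\S)C(C)Cn1ncccc1=O` gives 100 mg/kg. Compound 2 `C/N=C(\S)CCn1ncccc1=O` differs from compound 1 by hydrogen in place of methyl on a saturated chain carbon bound to a carbon with a double bond to nitrogen and a saturated chain carbon. In this assay compound 2 reaches only a limit, > 100 mg/kg. The step recorded is a number no lower from compound 1 to compound 2 (the limit leaves the size open). Compound 3 `Cc1ccc(=O)n(C(C)CC(=N)S)n1` has the same atoms as compound 1 joined differently; the difference between the two cores is not broken down here. In this assay compound 3 gives only a limit, > 100 mg/kg. Compound 4 `Cc1ccc(=O)n(CCC(=N)S)n1` differs from compound 3 by hydrogen in place of methyl on a saturated chain carbon bound to an aromatic nitrogen and a saturated chain carbon. The place is not the same as in the first pair, where the carbon carried a double-bonded nitrogen neighbour rather than an aromatic nitrogen, so this is the same kind of change, not the same change. Since compound 3 already sits at the limit of > 100 mg/kg in this assay, at which 2 of the 3 values shown sit, and the earlier removal of a methyl gave a number no lower from compound 1 to compound 2 (the limit leaves the size open), the expected step is a step that the limit leaves unreadable from compound 3 to compound 4. For compound 4 this assay is expected to give about 150 mg/kg, most likely between 70 mg/kg and 400 mg/kg, and probably again only as a limit.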

Compound 4, dose for half-maximal effect: 43.2 mg/kg
Compound 4: the middle estimate sits 3.5-fold (0.54 log units) above what was measured; the measured number lies below the stated range.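

In this assay, hydrogen in place of methyl on a saturated chain carbon bound to an aromatic nitrogen and a saturated chain carbon gives an at least 2.3-fold lower number from compound 3 to compound 4 (0.36 log units; beyond the scatter), so on the core of compound 3 the change goes with an effect at smaller amounts. Set beside the first pair, the result does not show that the change carries over from one core to the other, nor that it fails to: the same change on two cores in this assay, a number no lower (the limit leaves the size open) from compound 1 to compound 2 and an at least 2.3-fold lower number (0.36 log units; beyond the scatter) from compound 3 to compound 4; the limit leaves it open whether they differ

The two changes also sit at different places, so even a readable match would compare the same kind of change, not the same change, and a shared limit marks much of this small set: the limit of > 100 mg/kg in this assay, at which 2 of the 4 values shown sit.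

The compounds shown leave open how an ethyl group or a longer chain on the same carbon would compare with methyl and hydrogen. They also leave open whether an amine or a hydroxyl group there would fit with the step seen on this core.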